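The source may hold more compounds than are shown below. What is called first, only, known or untested is meant among the compounds shown, and "the series" means these compounds.

The series is examined in an assay on a subcellular fraction from brain for inhibition of Norepinephrine transporter (Rattus norvegicus); on this read-out lower numbers stand for stronger inhibition and higher numbers for weaker inhibition. Compound 1, with structure `COC(=O)[C@@H]1CN(C)CC[C@@H]1c1ccc2ccccc2c1`, gives 34 nM. Compound 2, with structure `COC(=O)[C@H]1CN(C)CC[C@@H]1c1ccc2ccccc2c1`, gives 241 nM, and the step of a 7.1-fold higher number from compound 1 to compound 2 (0.85 log units; beyond the scatter) rests on (the fact that compounds 1 and 2 differ only in the configuration as drawn). Compound 3, with structure `C=Cc1ccc([C@H]2CCN(C)C[C@H]2C(=O)OC)cc1`, gives 175 nM; on these three numbers compound 3 stands second highest, closest to compound 2 and within the scatter of it, while compound 1 sits well below both.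

Compound 4, with structure `COC(=O)[C@@H]1CN(C)CC[C@@H]1c1ccc(-c2ccccc2)cc1`, has not yet been measured in this assay. Compared with compound 3 it carries phenyl in place of vinyl on an aromatic carbon, phenyl in place of vinyl on an aromatic carbon. Among the compounds with values here, the only measured step, from compound 1 to compound 2, is a change of configuration alone and so says nothing about replacing a substituent on the aromatic ring. What can be said is that compound 1, which bears a larger aromatic system at the same end of the core, gives the lowest number of the three, and that compound 3 with its vinyl sits higher. On this slender basis a lower number is expected for compound 4, with the step of a 2.2-fold lower number from compound 3 to compound 4 (0.34 log units; beyond the scatter) estimated as modest at most. Compound 4 is therefore estimated at 80 nM, within a range from 20 nM to 400 nM.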

Compound 4, inhibition constant: 203 nM
Beside the measured number, compound 4's estimate is 2.5-fold (0.40 log units) below it, within the range that was stated.
By their numbers in this assay, from the lowest: compound 1; then compounds 3, 4 and 2 (each within the scatter of the next).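

In this assay, within the data shown here, the step of a 1.2-fold higher number from compound 3 to compound 4 (0.06 log units; within the scatter) is the first reading of a substituent change on the aromatic ring, since the only earlier step concerned configuration alone. At this place, on an aromatic carbon para to a large group, phenyl with its 6 heavy atoms and one six-membered aromatic ring stands in for vinyl with its 2 heavy atoms and a double bond, and the read-out does not separate the two groups, so on this pair the added ring and the added heavy atoms leave no mark beyond the scatter. None of the evidence available bears on this step, so no reason can be offered for why these two groups read alike.

What the compounds shown leave open is whether this holds for groups of another kind at the same place, such as an amine, a carboxylic acid or a methoxy group, or for a longer chain such as hexyl. Going by these compounds, it is also open whether the configuration step seen for the earlier pair would be of similar size if phenyl or vinyl stood on the ring in place of the aromatic system of that pair.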